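Swapping the nitro-bearing ring for a dichlorophenyl in compound 4

This account rests on a few compounds, and the source may have more. Where it says the series, first, only, none or still open, it means among the compounds named here.

Of the compounds shown here, three that share one core have been measured in a functional assay on MGC-803 cells (Homo sapiens) for inhibition, read by MTT assay, with a stated time of 72 h; a higher number here means a weaker inhibitor, a lower number a stronger inhibitor. Compound 1 `O=C(/C=C/c1ccc(Oc2ncnc3ccc(Cl)cc23)cc1)/C=C/c1c(Cl)cccc1Cl` gives 6770 nM, compound 3 `O=C(/C=C/c1ccc(Oc2ncnc3ccc(Cl)cc23)cc1)/C=C/c1cccc(Cl)c1Cl` gives 7300 nM, and compound 2 `O=C(/C=C/c1cc([N+](=O)[O-])ccc1Cl)/C=C/c1ccccc1Oc1ncnc2ccc(Cl)cc12` gives 1960 nM. Compound 2 thus stands lowest of the three numbers, with compound 1 the nearest and compound 3 the furthest, both separated from it by steps described as beyond the scatter.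

Compound 4 `O=C(/C=C/c1ccccc1Oc1ncnc2ccc(Cl)cc12)/C=C/c1cccc(Cl)c1Cl` has not yet been measured. Relative to compound 2 the change is 2,3-dichlorophenyl in place of 2-chloro-5-nitrophenyl on a double-bonded chain carbon bound to a double-bonded chain carbon. For the measured compounds named here, no measured step follows exactly this exchange. Going by the values given here, the only step among the measured compounds that touches the same ring position is a 1.1-fold higher number from compound 1 to compound 3 (0.03 log units; within the scatter), which moved one chlorine around the ring without a nitro group being involved and stayed within the scatter. Compound 3 carries the same 2,3-dichlorophenyl as compound 4, but it also differs from compound 2 in how the core is attached, so its value alone cannot separate the two changes. Among the compounds with values here, the loss of the nitro group therefore has no direct precedent here, and a modest rise in this assay is expected, a 2.0-fold higher number from compound 2 to compound 4 (0.31 log units; beyond the scatter). Compound 4 is accordingly estimated at 4000 nM, within a range of 1500 nM to 11000 nM.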

Compound 4, half-maximal inhibitory concentration: 5210 nM
Beside the measured number, compound 4's estimate is 1.3-fold (0.11 log units) below it; low and high end bracket the measured number.
By their numbers in this assay, from the lowest: compound 2; then compounds 4, 1 and 3 (each within the scatter of the next).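

In this assay, for the compounds shown here, the exchange of 2-chloro-5-nitrophenyl for 2,3-dichlorophenyl gives the first direct reading of this place with the rest of the molecule unchanged, and it gives a 2.7-fold higher number from compound 2 to compound 4 (0.42 log units; beyond the scatter), a modest step. Going by these compounds alone, the only earlier step at this place, a 1.1-fold higher number from compound 1 to compound 3 (0.03 log units; within the scatter), moved one chlorine around the ring on a different attachment of the core, so it could not show that replacing the whole substituted ring here would register beyond the scatter. Nothing available explains why the number rises with this exchange.

The exchange removes the nitro group and adds a second chlorine in a single step, and the compounds shown do not separate these two contributions. On these data alone, it also remains open whether an amine or a carboxylic acid in place of the nitro group on the 2-chloro-5-nitrophenyl ring would hold the number near that of compound 2 at 1960 nM or move it further.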